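This account rests on a few compounds, and the source may have more. Where it says the series, first, only, none or still open, it means among the compounds named here.

Measured so far in a functional assay on OVCAR-3 cells (Homo sapiens) for inhibition, read by sulforhodamine B assay, with a stated time of 48 h; a higher number here means that more compound is tolerated, a lower number that less compound is tolerated:
Compound 1 `COc1cc(-c2nn(-c3cccc(NC(=O)Nc4ccc(Cl)c(Cl)c4)c3)cc2-c2ccncc2)ccc1Cl`: compound 1 gives > 50000 nM, a limit of the assay.
Compound 2 `O=C(Nc1cccc(-n2cc(-c3ccncc3)c(-c3ccc(Cl)c(O)c3)n2)c1)Nc1ccc(Cl)c(Cl)c1`: compound 2 gives > 32500 nM, also a limit of the assay.
Compound 3 `O=C(Nc1cccc(-n2cc(-c3ccncc3)c(-c3ccc(Cl)c(O)c3)n2)c1)Nc1cc(C(F)(F)F)cc(C(F)(F)F)c1`: compound 3 gives 3310 nM.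

Compound 1 stands at a limit in this assay, and only a limit is known for it. Two of the three values shown are limits (the limit of > 50000 nM in this assay, at which 1 of the 3 values shown sits, and (the limit of > 32500 nM in this assay, at which 1 of the 3 values shown sits)); compound 3 alone gives a number. Among the compounds with values here, the only step between measured compounds, a step that the two limits leave unreadable from compound 1 to compound 2, has a limit at both ends and says nothing about size.

Compound 4 `COc1cc(-c2nn(-c3cccc(NC(=O)Nc4ccc(Cl)c(C(F)(F)F)c4)c3)cc2-c2ccncc2)ccc1Cl` differs from compound 1 by trifluoromethyl in place of chloro on an aromatic carbon. Within the data shown here, no measured step covers this change. The nearest hint is the pair compound 2 and compound 3: compound 3, which carries two trifluoromethyl groups in place of the two chloro groups of compound 2, gives a number where compound 2 gives only a limit. Compound 4 swaps a single chloro for trifluoromethyl, a smaller change, so a step of an at least 1.6-fold lower number from compound 1 to compound 4 (0.22 log units; that floor lies within the scatter) is expected, read with caution from a limit. Compound 4 is estimated at 30000 nM, between 8000 nM and 80000 nM, with a real chance that this assay again reports only a limit.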

Compound 4, concentration lethal to 50% of the cells: > 32500 nM
Compound 4 gave a limit, no number; the forecaster's own chance of this, stated with the estimate: 55%; middle value at least 1.0-fold (0.03 log units) from the limit.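

Compound 1 and compound 4 both stand at a limit in this assay, so the step between them cannot be read. The compounds shown leave open whether trifluoromethyl in place of chloro changes the value on the core of compound 1 at all.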